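Amide aryl swap on the long-chain thioether series

This account rests on a few compounds, and the source may have more. Where it says the series, first, only, none or still open, it means among the compounds named here.

Compound 3 `Cn1c(Cc2nn(C)c(=O)c3ccccc23)nnc1SCCCCCCCC(=O)Nc1ccc(O)cc1O` gives 17000 nM in an assay on isolated protein (Mus musculus) for inhibition of IL15-IL15 receptor (Homo sapiens), read by resazurin assay, with stated times of 30 min and 2.5 days; a higher number here means a weaker inhibitor, a lower number a stronger inhibitor. Compound 2 `Cn1c(Cc2nn(C)c(=O)c3ccccc23)nnc1SCCCCCCCCCCC(=O)Nc1ccccc1Cl` gives 15000 nM in this assay, and the two numbers sit within the scatter of each other, so neither stands apart. Compound 1 `CCCOc1ccc(NC(=O)CSc2nnc(Cc3nn(C)c(=O)c4ccccc34)n2C)cc1` gives only a limit, > 30000 nM, in this assay; (the limit of > 30000 nM in this assay, at which 1 of the 3 values shown sits). Compound 4 `COc1ccc(NC(=O)CCCCCCCSc2nnc(Cc3nn(C)c(=O)c4ccccc34)n2C)cc1` is not yet measured. It differs from compound 3 in one place: 4-methoxyphenyl in place of 2,4-dihydroxyphenyl on an amide-type nitrogen. Among the compounds with values here, no step between measured compounds carries this change, so the expectation rests on the numbers alone. For compound 4 the estimated step from compound 3 is a 1.2-fold higher number from compound 3 to compound 4 (0.07 log units; within the scatter), not beyond the scatter. Compound 4 is therefore expected to give about 20000 nM in this assay, within 8000 nM to 60000 nM.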

Compound 4, half-maximal inhibitory concentration: 3900 nM
Compound 4: the middle estimate sits 5.1-fold (0.71 log units) above what was measured; measured number outside the range, below it.
By their numbers in this assay, from the lowest: compound 4; then compounds 2 and 3 (each within the scatter of the next). At a limit, above all of these: compound 1.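

At the amide-type nitrogen of this long-chain thioether series, the aryl group does move the number: in this assay the change to 4-methoxyphenyl from 2,4-dihydroxyphenyl gives a 4.4-fold lower number from compound 3 to compound 4 (0.64 log units; beyond the scatter) as a modest step. The entering group has 0 hydrogen-bond donors and the leaving group has 2, but nothing measured here ties the step to that difference. Still open, going by these compounds, is whether a single hydroxyl or a single methoxy group on the phenyl would account for the step. On these data alone, how an amine or a carboxylic acid would read at this position is also open.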